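Swapping bromo for chloro in the aryl ether series

A few compounds are considered here, and "the series" means these few. Any claim that something is new, unique, unknown or untested is made for them only; others in the source may bear on it.

Measured in a functional assay on A549 cells (Homo sapiens) for antiproliferative activity, read by MTT assay, with a stated time of 72 h; on this read-out higher numbers stand for weaker inhibition and lower numbers for stronger inhibition:
- compound 1 `COc1ccc(OCCCON2C(N)=NC(N)=NC23CCOCC3)cc1`: 660 nM
- compound 2 `NC1=NC2(CCOCC2)N(OCCCOc2cccc(Br)c2)C(N)=N1`: 160 nM

Of the two measured compounds, compound 2 has the lower number, 160 nM. Compound 3 `NC1=NC2(CCOCC2)N(OCCCOc2cccc(Cl)c2)C(N)=N1` differs from it in one place: chloro in place of bromo on an aromatic carbon. This puts chloro in place of bromo on an aromatic carbon, meta to a large group. Going by the values given here, the only measured step, a 4.1-fold lower number from compound 1 to compound 2 (0.62 log units; beyond the scatter), bears on this loosely, since it exchanges a whole substituted phenyl group and not one halogen for another. No step beyond the scatter is therefore expected in this assay, and no direction is favoured. The estimated change is a 1.3-fold higher number from compound 2 to compound 3 (0.10 log units; within the scatter). For compound 3 the expected value is 200 nM, with an expected range of 90 nM to 420 nM.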

Compound 3, half-maximal inhibitory concentration: 150 nM
Beside the measured number, compound 3's estimate is 1.3-fold (0.12 log units) above it; low and high end bracket the measured number.
By their numbers in this assay, from the lowest: compounds 3 and 2 (each within the scatter of the next); then compound 1.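

In this assay, chloro and bromo on this aromatic carbon are not told apart, with a 1.1-fold lower number from compound 2 to compound 3 (0.03 log units; within the scatter) as the step for this exchange. The gain over the 4-methoxyphenyl group is kept with the lighter halogen, with a 4.4-fold lower number from compound 1 to compound 3 (0.64 log units; beyond the scatter) as the step, so it is not tied to 3-bromophenyl alone. No evidence is at hand to explain either result.

Open, as far as these compounds go, is whether fluoro, trifluoromethyl or nitrile on this carbon would give a similar number. Also open, from the compounds shown here alone, is how plain phenyl or a longer chain would compare.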